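From Methoxy to Nitro on an Aromatic Ring

The source may hold more compounds than are shown below. What is called first, only, known or untested is meant among the compounds shown, and "the series" means these compounds.

Of the compounds shown here, three sharing one core have been measured in an ADME assay on PC-12 cells (Rattus norvegicus) for cytotoxicity, read by MTT assay, with a stated time of 24 h; a higher number here means that more compound is tolerated, a lower number that less compound is tolerated. There, compound 1 `Cc1c(-c2nnc(-c3ccccc3)o2)sc2ncnc(N3CCCCC3)c12` gives 146 ug/mL, compound 2 `Cc1ccc(-c2nnc(-c3sc4ncnc(N5CCCCC5)c4c3C)o2)cc1` gives 161 ug/mL and compound 3 `COc1ccc(-c2nnc(-c3sc4ncnc(N5CCCCC5)c4c3C)o2)cc1` gives 124 ug/mL. Compound 3 therefore stands within the scatter of both others, so these numbers do not rank the three.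

Compound 4 `Cc1c(-c2nnc(-c3ccc([N+](=O)[O-])cc3)o2)sc2ncnc(N3CCCCC3)c12` differs from compound 3 by a single change: nitro in place of methoxy on an aromatic carbon. In words, this is nitro in place of methoxy on an aromatic carbon, para to a large group, turning 4-methoxyphenyl into 4-nitrophenyl.

For the measured compounds named here, three measured steps bear on this change. Methyl in place of hydrogen gave a 1.1-fold higher number from compound 1 to compound 2 (0.04 log units; within the scatter), methoxy in place of hydrogen gave a 1.2-fold lower number from compound 1 to compound 3 (0.07 log units; within the scatter), and methoxy in place of methyl gave a 1.3-fold lower number from compound 2 to compound 3 (0.11 log units; within the scatter). Each of these steps stays within the scatter. Going by the values given here, no nitro compound has been measured yet, so this is a thin basis, and the range has to stay wide. The expected step is a 1.1-fold higher number from compound 3 to compound 4 (0.04 log units; within the scatter), so no change beyond the scatter is anticipated in this assay. For compound 4 the estimated value is 135 ug/mL, with an expected range from 75 ug/mL to 240 ug/mL.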

Compound 4, half-maximal cytotoxic concentration: 145 ug/mL
Beside the measured number, compound 4's estimate is 1.1-fold (0.03 log units) below it, and the stated range covers the measured number.
By their numbers in this assay, from the lowest: compounds 3, 4, 1 and 2 (each within the scatter of the next).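

In this assay, nitro extends the set of groups tested at this position, para to a large group, and the outcome stays the same whichever group it replaces: methoxy (a 1.2-fold higher number from compound 3 to compound 4 (0.07 log units; within the scatter)), methyl (a 1.1-fold lower number from compound 2 to compound 4 (0.05 log units; within the scatter)) or hydrogen (a 1.0-fold lower number from compound 1 to compound 4 (0.00 log units; within the scatter)). All three steps lie within the scatter, so hydrogen, methyl, methoxy and nitro cannot be told apart here, and none of the four compounds goes against this, even though nitro enters with more heavy atoms and hydrogen-bond acceptors than methoxy. Nothing available explains why these groups give such similar numbers.

These four compounds leave open whether an amine, a carboxylic acid or a longer chain at this position would produce a step beyond the scatter. They also leave open whether nitro would behave the same way at another place on the six-membered ring, or on a compound in which the piperidine-free part of the shared core carries a different group.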